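Swapping a seven-membered ring for an amide-bearing pyrrolidine

A few compounds are considered here, and "the series" means these few. Any claim that something is new, unique, unknown or untested is made for them only; others in the source may bear on it.

Measured so far:
- compound 1 `Cc1nn([C@H](C)c2ccc(Cl)cc2Cl)c2nc(N3CC[C@H](N4CCC[C@H]4C(N)=O)[C@H](C)C3)cnc12`: "not determined" (no result reported)
- compound 2 `C[C@@H]1CC(c2cnc3c(C#N)nn([C@H](C)c4ccc(Cl)cc4Cl)c3n2)=CC[C@@H]1N1CCC[C@H]1C(N)=O`: 1380 nM
- compound 3 `Cc1nn([C@H](C)c2ccc(Cl)cc2Cl)c2nc(N3CC[C@H](N4CCCCCC4)[C@H](C)C3)cnc12`: 195 nM

In an assay on CCRF-CEM cells for antagonist activity at C-C chemokine receptor type 4 (Homo sapiens), read by CellTiter-Glo, with stated times of 30 min and 60 min, in the presence of a further agent that is not named here (a higher number here means a weaker inhibitor, a lower number a stronger inhibitor), compound 3 gives 195 nM and stands as the lower of the two numbers; compound 2, at 1380 nM, shows a higher number, a gap beyond the usual scatter. Compound 1 carries a closely related carboxamide but has no reported number.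

Compound 4 `Cc1nn([C@H](C)c2ccc(Cl)cc2Cl)c2nc(N3CC[C@H](N4CCC[C@H]4CCC(N)=O)[C@H](C)C3)cnc12` differs from compound 3 in one place: 2-(2-carbamoylethyl)pyrrolidin-1-yl in place of azepan-1-yl on a saturated ring carbon. Within the data shown here, no measured pair shows this exact change, so the expected direction is uncertain; a modest loss of potency is expected, with a 2.1-fold higher number from compound 3 to compound 4 (0.31 log units; beyond the scatter) as the anticipated step. Compound 4 is therefore estimated at 400 nM, expected to fall between 120 nM and 1500 nM.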

Compound 4, half-maximal inhibitory concentration: 355 nM
Compound 4: the middle estimate sits 1.1-fold (0.05 log units) above what was measured, within the range that was stated.
By their numbers in this assay, from the lowest: compounds 3 and 4 (each within the scatter of the next); then compound 2.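

In this assay, 2-(2-carbamoylethyl)pyrrolidin-1-yl in place of azepan-1-yl gives a 1.8-fold higher number from compound 3 to compound 4 (0.26 log units; within the scatter), so this saturated ring carbon can carry a larger group, with a five-membered ring, an amide and a hydrogen-bond donor, without a step beyond the scatter. The seven-membered ring is therefore not needed for a number in this range. On these data alone, compound 1, with its shorter carboxamide, gives "not determined" (no result reported), so its step cannot be read, and whether a carboxylic acid, an amine or a longer chain would hold this range stays open. Nothing measured here gives a reason for this result.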